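The source may report more compounds than this note shows. Statements on the series, on what has been measured and on what is new or still open speak of the compounds shown alone.

In a functional assay on cells (Platelet, Homo sapiens) for inhibition (on this read-out lower numbers stand for stronger inhibition and higher numbers for weaker inhibition), compound 1 (`CCOC(=O)c1ccc(-c2nn(Cc3ccc(F)cc3)c3ccccc23)cc1`) gives > 10000 nM as a limit of the assay and not a number. Compound 2 (`CCOC(=O)c1ccc(-c2nn(Cc3ccccc3OC)c3ccccc23)cc1`) gives > 10000 nM and this too is a limit. Compound 3 (`CCOC(=O)c1ccc(-c2nn(Cc3ccncc3)c3ccccc23)cc1`) stands at > 10000 nM which is likewise a limit and not a number. The three compounds thus share a single reading (the limit of > 10000 nM in this assay, at which 3 of the 3 values shown sit). Compound 4 (`CCCCn1nc(-c2ccc(C(=O)OCC)cc2)c2ccccc21`) departs from compound 3 by one change (propyl in place of pyridin-4-yl on a saturated chain carbon bound to an aromatic nitrogen), namely propyl in place of pyridin-4-yl on a saturated chain carbon bound to an aromatic nitrogen. Within the data shown here, three measured steps bear on that place (a step that the two limits leave unreadable from compound 1 to compound 2; a step that the two limits leave unreadable from compound 1 to compound 3; a step that the two limits leave unreadable from compound 2 to compound 3) and none of them has a readable size. Among the measured compounds shown here, each swaps one aromatic group for another, and no compound with an open chain there has been measured. For the measured compounds named here, no step of readable size is therefore expected in this assay, and no direction can be argued with confidence. The estimate amounts to a step that the limit leaves unreadable from compound 3 to compound 4 as the expected step. Compound 4 is expected at 12000 nM within an estimated range from 4000 nM to 30000 nM and may well return only a limit.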

Compound 4, half-maximal inhibitory concentration: > 10000 nM
Compound 4: no number, only a limit; the forecaster's own chance of this, stated with the estimate: 80%; the middle value does not contradict the limit.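

Compound 4 gives > 10000 nM in this assay, again a limit and not a number, so its steps from compound 1, compound 2 and compound 3 cannot be read. The compounds shown leave open whether the group at this place affects inhibition at all, with every reading the same: the limit of > 10000 nM in this assay, at which 4 of the 4 values shown sit.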